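A few compounds are considered here, and "the series" means these few. Any claim that something is new, unique, unknown or untested is made for them only; others in the source may bear on it.

- compound 1 `CCc1ccc(-c2nc3ccccn3c2Sc2ccccc2)cc1`: 84500 nM
- compound 2 `c1ccc(Sc2c(-c3cccc4ccccc34)nc3ccccn23)cc1`: 60600 nM

In a functional assay on DU-145 cells (Homo sapiens) for inhibition, read by MTT assay, with a stated time of 48 h (a lower number here means a stronger inhibitor, a higher number a weaker inhibitor), compound 1 gives 84500 nM and compound 2 gives 60600 nM in the same test. For the measured compounds named here, these two values lie within the scatter of each other, so compound 1 stands level with the only other measured compound. Compound 3 `C(=C/c1nc2ccccn2c1Sc1ccccc1)\c1ccccc1` is still unmeasured. It carries 2-phenylethenyl in place of 4-ethylphenyl on an aromatic carbon of the core of compound 1. Going by the values given here, no measured step covers this change, so no shift beyond the scatter is expected in either direction. The estimated step of a 1.4-fold lower number from compound 1 to compound 3 (0.15 log units; within the scatter) is therefore expected to be small. For compound 3 the estimated value is 60000 nM with an expected range from 20000 nM to 130000 nM in this test.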

Compound 3, half-maximal inhibitory concentration: 22000 nM
Compound 3: the middle estimate sits 2.7-fold (0.44 log units) above what was measured; low and high end bracket the measured number.
By their numbers in this assay, from the lowest: compound 3; then compounds 2 and 1 (each within the scatter of the next).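

For the compounds shown here, replacing 4-ethylphenyl with 2-phenylethenyl on this aromatic carbon gives a 3.8-fold lower number from compound 1 to compound 3 (0.58 log units; beyond the scatter) in this assay, showing for the first time that this position can respond beyond the scatter. Both groups have 8 heavy atoms and one six-membered aromatic ring of carbon only, and the entering group adds a double bond outside aromatic rings. No measurement at hand explains the step. The compounds shown leave open how 2-phenylethyl would compare at this position, which would test the double bond directly. They also leave open how an amine on the ring of the 2-phenylethenyl group would read.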